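Swapping a dichlorophenyl ketone for a dimethoxyphenyl ketone

The compounds below may be only part of what the source reports. "The series", "measured", "known", "first", "only" and "open" are said of these compounds alone.

Measured compounds:
compound 1, `COc1ccc(-c2cc(/C=C/C(=O)c3ccc(OC)c(OC)c3)[nH]n2)cc1`, 3590 nM
compound 2, `COc1cc(-c2cc(/C=C/C(=O)c3ccc(Cl)c(Cl)c3)[nH]n2)cc(OC)c1OC`, 79600 nM
compound 3, `COc1ccc(-c2cc(/C=C/C(=O)c3ccc(N)cc3)[nH]n2)cc1OC`, 6940 nM

All three were tested in a functional assay on SW-620 cells (Homo sapiens) for inhibition, read by sulforhodamine B assay, with a stated time of 48 h; a lower number here means a stronger inhibitor of growth, a higher number a weaker inhibitor of growth. Compound 2 stands at the highest number of the three, which makes it the weakest inhibitor of growth in this set; the gaps to compound 3 and to compound 1 both lie beyond the scatter of repeated measurements, with compound 1 at the lowest number of the three.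

Compound 4, `COc1ccc(C(=O)/C=C/c2cc(-c3cc(OC)c(OC)c(OC)c3)n[nH]2)cc1OC`, has not yet been measured. It shares the core of compound 2 and differs only at the ketone: 3,4-dimethoxyphenyl in place of 3,4-dichlorophenyl on a carbonyl carbon. For the measured compounds named here, no pair of measured compounds that differs in one place is available, so the size of this step cannot be read off directly. What the measured compounds do show is that compound 1 and compound 3, which both carry methoxy or amino substituents on the aryl ketone, sit at far lower numbers than compound 2 with its dichlorophenyl ketone. On that basis compound 4 is expected to move to a lower number, with a step of a 16-fold lower number from compound 2 to compound 4 (1.20 log units; beyond the scatter) anticipated. The estimate for compound 4 in this assay is 5000 nM, with a likely range from 1500 nM to 20000 nM.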

Compound 4, concentration for total growth inhibition: 2990 nM
Estimate against measurement, compound 4: 1.7-fold (0.22 log units) above; the range from low to high includes it.
By their numbers in this assay, from the lowest: compounds 4, 1 and 3 (each within the scatter of the next, the first and the last beyond it); then compound 2.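

In this assay, exchanging the 3,4-dichlorophenyl on a carbonyl carbon for 3,4-dimethoxyphenyl gives a 27-fold lower number from compound 2 to compound 4 (1.43 log units; beyond the scatter) and is a large step, beyond the scatter. For the compounds shown here, the earlier compounds differed from one another in more than one place, so this is the first change in the set that can be read on its own, and it shows that the group on the carbonyl carbon alone can move the number this far while the rest of the structure of compound 2 stays the same. Nothing measured here bears on why the step is this large.

From the compounds shown here alone, it remains open whether a single methoxy group would be enough to give such a step, and whether the same change would give a step of similar size on the core of compound 1 or compound 3. The compounds shown also leave open how a carboxylic acid or a morpholine would read in place of the 3,4-dimethoxyphenyl on the carbonyl carbon.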